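The source may hold more compounds than are shown below. What is called first, only, known or untested is meant among the compounds shown, and "the series" means these compounds.

Measured compounds:
compound 1 `Cc1ccc(-c2cs/c(=N/NC(=O)CSc3nncn3C)n2-c2ccccc2)cc1`, giving 27.8%
compound 2 `Cc1ccc(-c2cs/c(=N/NC(=O)CSc3nnnn3C)n2-c2ccccc2)cc1`, giving 39.7%

Among the compounds with values here, compound 2 holds the highest of the two numbers in a functional assay on C6 cells (Rattus norvegicus) for cytotoxicity, read by MTT assay, with a stated time of 24 h, tested at 200 ug/mL (on this read-out lower numbers stand for a stronger effect and higher numbers for a weaker effect at the one concentration tested), and the one recorded step is a number 11.9 percentage points higher from compound 1 to compound 2 (beyond the scatter), a change of the heteroaryl group on the sulfur. Compound 3 `Cn1nnnc1SCC(=O)N/N=c1/scc(-c2ccccc2)n1-c1ccccc1` differs from compound 2 elsewhere: hydrogen in place of methyl on an aromatic carbon, on an aromatic carbon of a six-membered aromatic ring of carbon only, para to a large group. Within the data shown here, no measured step bears on this change; the step of a number 11.9 percentage points higher from compound 1 to compound 2 (beyond the scatter) concerns a different part of the molecule and gives no guidance on removing a methyl from the 4-methylphenyl group. With nothing to indicate either direction, no step beyond the scatter is expected in this assay. Compound 3 is therefore estimated at 40%, with a range from 27% to 53%. This expectation amounts to a number 0.3 percentage points higher from compound 2 to compound 3 (within the scatter).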

Compound 3, a percentage reported as activity, at one concentration (the size of the read-out at that concentration, not a potency): 26.8%
Compound 3: the middle estimate sits 13.2 percentage points above what was measured; measured number below the stated range.
By their numbers in this assay, from the lowest: compounds 3 and 1 (each within the scatter of the next); then compound 2.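

In this assay the methyl of the 4-methylphenyl group turns out to count: going to phenyl gives a number 12.9 percentage points lower from compound 2 to compound 3 (beyond the scatter) on this read-out, so this place on the ring, para to a large group, influences the result just as the heteroaryl group on the sulfur does. Lower numbers stand for a stronger effect here, so removing the methyl strengthens the effect at the one concentration tested, with the tetrazole-bearing side of the molecule unchanged. Nothing available explains this step.

As far as these compounds go, it remains open how a chlorine atom, a methoxy group or an amine in the same place would compare with methyl and hydrogen. The compounds shown also leave open whether removing the methyl would do the same with the 4-methyl-4H-1,2,4-triazol-3-yl group on the sulfur.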